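Adding a Methoxy Group to Compound 2

A few compounds are considered here, and "the series" means these few. Any claim that something is new, unique, unknown or untested is made for them only; others in the source may bear on it.

Values so far in a functional assay on Huh-7 cells (Homo sapiens) for inhibition, read by MTT assay, with a stated time of 48 h (a higher number here means a weaker inhibitor, a lower number a stronger inhibitor), are
- compound 1 `O=C(/C=C/c1coc2cc(O)ccc2c1=O)NCc1ccccc1` gives 4690 nM
- compound 2 `COc1ccc2c(=O)c(/C=C/C(=O)Nc3ccccc3)coc2c1` gives 9050 nM

For the measured compounds named here, the numbers for compound 2 and compound 1 lie within the usual scatter of each other, so these two compounds cannot be told apart in this assay and compound 2 stands level with its only neighbour. Compound 3 `COc1ccc(NC(=O)/C=C/c2coc3cc(OC)ccc3c2=O)cc1` differs from compound 2 in one place (methoxy in place of hydrogen on an aromatic carbon), with methoxy in place of hydrogen on an aromatic carbon, turning phenyl into 4-methoxyphenyl. Going by the values given here, no measured pair shows what this change does, so no firm direction can be argued, and a shift no larger than the scatter is expected. The expected step is a 1.1-fold lower number from compound 2 to compound 3 (0.05 log units; within the scatter) in size. For compound 3 the estimated value is 8000 nM (expected range 2800 nM to 21000 nM).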

Compound 3, half-maximal inhibitory concentration: > 100000 nM
Compound 3: only a limit was reported; the forecaster's own chance of this, stated with the estimate: 10%; middle value at least 12-fold (1.09 log units) from the limit.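

The change from phenyl to 4-methoxyphenyl is not neutral: it brings an at least 11-fold higher number from compound 2 to compound 3 (1.04 log units; beyond the scatter) in this assay, so a methoxy at this place, para to a large group, can cost a great deal of inhibition in these cells. Compound 1 and compound 2 could not show this, as they differ from each other in more than one place. On these data alone, the value for compound 3 is a limit of the assay and not a number, so the full size of the loss stays unknown: the limit of > 100000 nM in this assay, at which 1 of the 3 values shown sits.

Whether the loss belongs to methoxy itself or would follow any group here stays open, as a fluorine, an amine or a carboxylic acid at this place is not among the compounds shown. Why a single methoxy has so large an effect cannot be read from these three compounds.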